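Hydroxy for Fluoro on the Sulfonyl Aryl Ring

The source may hold more compounds than are shown below. What is called first, only, known or untested is meant among the compounds shown, and "the series" means these compounds.

Compound 1, `COc1ccc(S(=O)(=O)c2cc3cnc(Nc4ccc5[nH]ccc5c4)nc3n(C)c2=O)cc1`, gives 350 nM in an assay on isolated protein for inhibition of serine/threonine-protein kinase PLK2 (Homo sapiens), read by scintillation counting and 33P incorporation, with a stated time of 30 min, in the presence of a further agent that is not named here; a lower number here means a stronger inhibitor, a higher number a weaker inhibitor.
Compound 2, `Cn1c(=O)c(S(=O)(=O)c2ccc(F)cc2)cc2cnc(Nc3ccc4[nH]ccc4c3)nc21`, gives 1070 nM in this assay.

Among the measured compounds shown here, compound 2 stands highest of the two numbers in this assay; the nearest is compound 1, and the only measured step, a 3.1-fold higher number from compound 1 to compound 2 (0.49 log units; beyond the scatter), is that exchange of methoxy for fluoro. Compound 3, `Cn1c(=O)c(S(=O)(=O)c2ccc(O)cc2)cc2cnc(Nc3ccc4[nH]ccc4c3)nc21`, is not yet measured. It differs from compound 2 in one place: hydroxy in place of fluoro on an aromatic carbon. For the measured compounds named here, no step with a hydroxy group has been measured, so the expectation rests on the single step that touches the same position. Because compound 1 to compound 2 showed a 3.1-fold higher number from compound 1 to compound 2 (0.49 log units; beyond the scatter) when an oxygen-bearing group gave way to fluoro, the return of an oxygen-bearing group is expected to move the number back down, though by less than the full width of that step, since hydroxy is not methoxy. The step from compound 2 to compound 3 in this assay is estimated at a 2.1-fold lower number from compound 2 to compound 3 (0.33 log units; beyond the scatter). Compound 3 is therefore expected to give about 500 nM in this assay, within a range from 150 nM to 1500 nM.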

Compound 3, half-maximal inhibitory concentration: 470 nM
For compound 3 the middle estimate is 1.1-fold (0.03 log units) above the measured one, within the range that was stated.
By their numbers in this assay, from the lowest: compounds 1 and 3 (each within the scatter of the next); then compound 2.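

In this assay, hydroxy on the 4-hydroxyphenyl ring gives a 2.3-fold lower number from compound 2 to compound 3 (0.36 log units; beyond the scatter), so a second oxygen-bearing group now stands at this place on the sulfonyl aryl ring, and it too lies on the lower side of fluoro. Hydrogen in place of methyl on that oxygen gives a 1.3-fold higher number from compound 1 to compound 3 (0.13 log units; within the scatter), so hydroxy and methoxy cannot be told apart here, and among these three compounds only fluoro stands apart, with compound 1 and compound 3 both showing lower numbers than compound 2. The data shown offer no measurement that could explain this difference between fluoro and the two oxygen-bearing groups.

The compounds shown leave open whether the higher number of compound 2 belongs to fluoro alone or would also appear with chloro, or with plain hydrogen at the same place. They also leave open how far the oxygen can be built on, since a longer chain such as ethoxy or benzyloxy, or a different attached atom as in an amine or a carboxylic acid, would test whether this place tolerates more than hydroxy and methoxy.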